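The compounds below may be only part of what the source reports. "The series", "measured", "known", "first", "only" and "open" are said of these compounds alone.

Compound 1 `CCCCCCCCCCc1ccc(-c2noc(CN)n2)cc1` gives 62% in an assay on HeLa cells for inhibition of sphingosine-1-phosphate transporter SPNS2 (Mus musculus), read by LC-MS, tested at 2 uM; a lower number here means less inhibition, a higher number more inhibition at the concentration tested (going by the name of the read-out). Compound 2 `CCCCCCCCCCc1ccc(-c2noc(CCCCN)n2)cc1` gives 55%. Compound 3 `CCCCCCCCCCc1ccc(-c2noc(CC3CCNC3)n2)cc1` gives 44%.

Compound 2 stands second highest of the three: compound 1 differs from it by a number 7 percentage points lower from compound 1 to compound 2 (within the scatter), while compound 3 lies a number 11 percentage points lower from compound 2 to compound 3 (beyond the scatter). Compound 4 `CCCCCCCCCCc1ccc(-c2noc([C@@H]3CCNC3)n2)cc1` differs from compound 2 in one place: pyrrolidin-3-yl in place of 4-aminobutyl on an aromatic carbon. Among the compounds with values here, the closest measured step is the one from compound 2 to compound 3, where the same ring replaced an open chain on a saturated chain carbon and gave a number 11 percentage points lower from compound 2 to compound 3 (beyond the scatter); the step of a number 18 percentage points lower from compound 1 to compound 3 (beyond the scatter) points the same way. A modest drop in this assay is therefore expected, namely a number 10 percentage points lower from compound 2 to compound 4 (within the scatter). Compound 4 is thus estimated at 45%, with a likely range from 30% to 60%.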

Compound 4, a percentage reported as inhibition, at one concentration (the size of the read-out at that concentration, not a potency): 62%
Compound 4: the middle estimate sits 17 percentage points below what was measured; measured number outside the range, above it.
By their numbers in this assay, from the lowest: compound 3; then compounds 2, 1 and 4 (each within the scatter of the next).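

In this assay, pyrrolidin-3-yl placed directly on the aromatic carbon keeps the number in the range of the open chains, with a number 7 percentage points higher from compound 2 to compound 4 (within the scatter) and no change at the digits printed from compound 1 to compound 4 (within the scatter). The same ring held one carbon further out, as (pyrrolidin-3-yl)methyl, reads differently, with a number 18 percentage points higher from compound 3 to compound 4 (beyond the scatter), so the ring alone does not bring a lower number and its point of attachment matters. No available measurement explains this difference.

Open, from the compounds shown here alone, is whether the opposite stereocentre of pyrrolidin-3-yl would give a similar number. Also open, going by these compounds, is how a piperidin-4-yl or azetidin-3-yl ring would behave on the same aromatic carbon.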